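Nitro in Place of Methyl on an Aromatic Ester

A few compounds are considered here, and "the series" means these few. Any claim that something is new, unique, unknown or untested is made for them only; others in the source may bear on it.

Among the measured compounds shown here, compound 2, `CC1=CC[C@H](C(C)C)c2cc(C)c(OC(=O)c3ccc(C)cc3)cc21`, stands highest of the three numbers measured so far in a functional assay on SK-LU-1 cells (Homo sapiens) for antiproliferative activity, read by sulforhodamine B assay, with a stated time of 48 h, tested at 50 uM; on this read-out lower numbers stand for less inhibition and higher numbers for more inhibition at the one concentration tested (going by the name of the read-out): compound 2 gives 85.4%. For the measured compounds named here, its nearest neighbour is compound 1, `COc1cccc(C(=O)Oc2cc3c(cc2C)[C@@H](C(C)C)CC=C3C)c1`, which gives 24.2% in this assay; the single change between the two, 4-methylphenyl in place of 3-methoxyphenyl on a carbonyl carbon, reads a number 61.2 percentage points higher from compound 1 to compound 2 (beyond the scatter). Compound 3, `Cc1cc2c(C(C)C)ccc(C)c2cc1OC(=O)c1cccc(C(F)(F)F)c1`, built on a different core, gives 17.3% in this assay and lies furthest from compound 2.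

The unmeasured compound 4, `CC1=CC[C@H](C(C)C)c2cc(C)c(OC(=O)c3ccc([N+](=O)[O-])cc3)cc21`, differs from compound 2 in one place: nitro in place of methyl on an aromatic carbon. The change sits on an aromatic carbon of a six-membered aromatic ring of carbon only, para to a large group. Going by the values given here, no measured step exchanges a group at that place, so only the step from compound 1 to compound 2 bears on it, and only loosely: it shows that a single change in the group on the carbonyl carbon can move this assay by a large amount, in either direction depending on what is exchanged. Among the compounds with values here, with no closer precedent, a step beyond the scatter is expected, more likely downward than upward, with wide uncertainty. Compound 4 is therefore expected to give about 45% in this assay, with a range from 12% to 80%. The step from compound 2 to compound 4 is thus estimated at a number 40.4 percentage points lower from compound 2 to compound 4 (beyond the scatter).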

Compound 4, a percentage reported as inhibition, at one concentration (the size of the read-out at that concentration, not a potency): 47.5%
For compound 4 the middle estimate is 2.5 percentage points below the measured one; measured number inside the range.
By their numbers in this assay, from the lowest: compounds 3 and 1 (each within the scatter of the next); then compound 4; then compound 2.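

In this assay the exchange at this aromatic carbon, para to a large group, gives a number 37.9 percentage points lower from compound 2 to compound 4 (beyond the scatter), so the activity of the 4-methylphenyl ester depends on the group held at this place and not only on the presence of a substituent there. The nitro group does not erase the advantage over the 3-methoxyphenyl ester, since the 4-nitrophenyl group still gives a number 23.3 percentage points higher from compound 1 to compound 4 (beyond the scatter), a modest step beside the large a number 61.2 percentage points higher from compound 1 to compound 2 (beyond the scatter), and so both groups at this place read above compound 1. Nothing available bears on what lies behind the drop from methyl to nitro.

Methyl and nitro are only two points at this place, so they set no trend, and it remains open whether an amine, a chlorine atom or a longer chain such as propyl would read nearer to compound 2 or to compound 4, or beyond either. The compounds shown also leave open whether the same exchange of methyl for nitro would move the number by a similar amount on the core of compound 3.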